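The source may report more compounds than this note shows. Statements on the series, on what has been measured and on what is new or still open speak of the compounds shown alone.

In an ADME assay on HEK293 cells (Homo sapiens) for cytotoxicity, with a stated time of 6 h (a higher number here means that more compound is tolerated, a lower number that less compound is tolerated), three compounds have been tested so far, and none of them gives an actual number. Compound 1 (`CCCCNc1nc(N)ncc1OCC`) reads > 25000 nM, which is a limit of the assay and not a number. Compound 2 (`CNc1nc(N)nc2ccccc12`) reads > 25000 nM, again a limit. Compound 3 (`CCNc1nc(N)nc2ccccc12`) reads > 25000 nM, also a limit. The whole picture is therefore a single observation: the limit of > 25000 nM in this assay, at which 3 of the 3 values shown sit.

Compound 4 (`CCCNc1nc(N)nc2ccccc12`) takes the side chain of compound 3 from ethylamino to propylamino, with a methyl in place of hydrogen on a saturated chain carbon, two bonds along the chain from a nitrogen on an aromatic ring.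

The closest measured change is a step that the two limits leave unreadable from compound 2 to compound 3. There too a methyl replaces a hydrogen on the chain, but its size cannot be read, so it offers no figure to carry forward. With only a step that the two limits leave unreadable from compound 2 to compound 3 as a guide, no step beyond the usual scatter is expected in this assay, and another limit is the most likely report. In numbers, the expected change is a step that the limit leaves unreadable from compound 3 to compound 4. The estimate for compound 4 is 30000 nM, with an expected range from 15000 nM to 60000 nM.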

Compound 4, half-maximal cytotoxic concentration: > 25000 nM
Compound 4 was reported as a limit; the forecaster's own chance of this, stated with the estimate: 85%; the middle value lies beyond the limit too.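

In this assay compound 4 gives > 25000 nM, a limit and not a number. The steps to compound 4 from compound 2 and from compound 3 cannot be read, and the picture remains a single observation: the limit of > 25000 nM in this assay, at which 4 of the 4 values shown sit.

The compounds shown leave open at what concentration any of them becomes toxic to the cells, and whether ethylamino to propylamino changes that concentration at all.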